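The source may hold more compounds than are shown below. What is called first, only, known or untested is meant among the compounds shown, and "the series" means these compounds.

Values in a functional assay on HepG2 cells (Homo sapiens) for inhibition, read by MTT assay, with a stated time of 72 h; on this read-out lower numbers stand for stronger inhibition and higher numbers for weaker inhibition:
compound 1 `Cc1cccc(CN2CCc3ncn(COCc4ccccc4)c3/C(=C/c3ccccc3)C2=O)c1`: 34300 nM
compound 2 `CC(C)(C)c1ccc(CN2CCc3ncn(COCc4ccccc4)c3/C(=C/c3ccccc3)C2=O)cc1`: 18000 nM
compound 3 `COc1cc(/C=C2\C(=O)N(Cc3ccccc3)CCc3ncn(COCc4ccccc4)c32)cc(OC)c1OC`: 10000 nM

Compound 3, at 10000 nM, lies within the usual scatter of compound 2 and has a clearly lower number than compound 1, which gives 34300 nM.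

Compound 4 `O=C1/C(=C\c2ccc(C(F)(F)F)cc2)c2c(ncn2COCc2ccccc2)CCN1Cc1ccccc1` has not yet been measured. It carries 4-(trifluoromethyl)phenyl in place of 3,4,5-trimethoxyphenyl on a double-bonded chain carbon bound to a double-bonded ring carbon.

Among the compounds with values here, only one measured step links two compounds that differ in a single place: a 1.9-fold lower number from compound 1 to compound 2 (0.28 log units; within the scatter). That step stays within the scatter, and it exchanges a group at another place, on a saturated chain carbon bound to an amide-type nitrogen in a ring. Within the data shown here, no measured step changes the group that differs here, so the data offer only indirect guidance. With so little to go on, compound 3 at 10000 nM is the natural starting point, and no step beyond the scatter is expected in this assay. The expected change, leaning slightly towards a higher number, is a 1.5-fold higher number from compound 3 to compound 4 (0.18 log units; within the scatter). For compound 4 the estimated value is 15000 nM, with an expected range of 6000 nM to 40000 nM.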

Compound 4, half-maximal inhibitory concentration: 51400 nM
Beside the measured number, compound 4's estimate is 3.4-fold (0.53 log units) below it, and the stated range ends below it.
By their numbers in this assay, from the lowest: compounds 3, 2, 1 and 4 (each within the scatter of the next, the first and the last beyond it).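

In this assay, placing 4-(trifluoromethyl)phenyl in place of 3,4,5-trimethoxyphenyl on the double-bonded chain carbon gives a 5.1-fold higher number from compound 3 to compound 4 (0.71 log units; beyond the scatter), so the group at this position can shift the number by more than the usual scatter. The only other single-place step, a 1.9-fold lower number from compound 1 to compound 2 (0.28 log units; within the scatter), concerns a different position, the saturated chain carbon bound to an amide-type nitrogen, and it stays within the scatter, so among these compounds only the change at the double-bonded chain carbon clearly moves the result. The two exchanged groups differ in their atoms and in their hydrogen-bond acceptors, but nothing available here links the step to any one of these differences.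

With only this one pair to compare, the compounds shown leave open whether all three methoxy groups matter or whether a simpler group, such as 4-methoxyphenyl or 4-hydroxyphenyl, would give a similar number. They also leave open whether the same step would appear with a different group on the ring nitrogen, such as a longer chain in place of the benzyl group of compound 3.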